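Iodo in place of furan-2-yl on compound 2

The source may report more compounds than this note shows. Statements on the series, on what has been measured and on what is new or still open speak of the compounds shown alone.

In a functional assay on HCT-116 cells (Homo sapiens), read by MTT assay, with a stated time of 72 h (on this read-out higher numbers stand for weaker inhibition and lower numbers for stronger inhibition), the three measured compounds offer little to work from. Compound 1 (`Nc1nc(N)c2c(-c3ccco3)cn([C@@H]3O[C@H](CO)[C@@H](O)[C@H]3O)c2n1`) reaches only a limit, > 20000 nM and no number. Compound 2 (`Cc1nc(N)c2c(-c3ccco3)cn([C@@H]3O[C@H](CO)[C@@H](O)[C@H]3O)c2n1`) also gives only a limit, > 20000 nM and no number. Going by these compounds, compound 2 therefore stands, with compound 1, at the limit of > 20000 nM in this assay, at which 2 of the 3 values shown sit, and its true value is unknown. Among the measured compounds shown here, compound 3 (`Nc1nc2c(c(-c3cccs3)cn2[C@@H]2O[C@H](CO)[C@@H](O)[C@H]2O)c(=O)[nH]1`) gives the only real number, 19800 nM and this shows no strong inhibition.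

Compound 4 (`Cc1nc(N)c2c(I)cn([C@@H]3O[C@H](CO)[C@@H](O)[C@H]3O)c2n1`) differs from compound 2 by one change: iodo in place of furan-2-yl on an aromatic carbon with iodo in place of furan-2-yl on an aromatic carbon. For the measured compounds named here, the only measured step is a step that the two limits leave unreadable from compound 1 to compound 2 and it is a different change, methyl in place of amino, so it offers no size to carry over. Going by the values given here, no measured step involves iodo, and the expectation therefore rests on weak evidence. With every measured compound weak in this assay a large gain is not expected, although some movement towards stronger inhibition is possible. The expected change is an at least 1.6-fold lower number from compound 2 to compound 4 (0.22 log units; that floor lies within the scatter) and it may remain unreadable if compound 4 also ends at the limit. The estimate for compound 4 is 12000 nM (expected range 2000 nM to 30000 nM).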

Compound 4, half-maximal inhibitory concentration: > 20000 nM
Compound 4: only a limit was reported (the forecaster's own chance of this, stated with the estimate: 50%); middle value at least 1.6-fold (0.22 log units) away from the limit.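

In this assay compound 4 gives > 20000 nM, which is a limit and not a number. Compound 2 also ends at a limit, so no step from compound 2 to compound 4 can be read; both stand at the same place: the limit of > 20000 nM in this assay, at which 3 of the 4 values shown sit.

The compounds shown leave open whether iodo in place of furan-2-yl changes inhibition at all, and in which direction.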